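Solubility notes: acrylamide benzimidazole series, piperidinyl amide variant

The compounds below may be only part of what the source reports. "The series", "measured", "known", "first", "only" and "open" are said of these compounds alone.

Two members of this series have been run in a physicochemical assay for solubility, at pH 7.4; a lower number here means a less soluble compound, a higher number a more soluble compound. Compound 1 is `C=CC(=O)Nc1cc(-n2c(-c3nc(-c4cnn(C5CCN(C)CC5)c4)cnc3N)nc3ccccc32)ccc1OC`; in this assay compound 1 gives < 10000 nM, which is a limit of the assay rather than a number. Compound 2 is `C=CC(=O)Nc1cccc(-n2c(-c3nc(-c4cnn(C)c4)cnc3N)nc3ccccc32)c1`; in this assay compound 2 gives < 10000 nM, again a limit of the assay. Among the measured compounds shown here, compound 2 therefore stands only at a limit, and the other value shown is a limit as well, so no measured step between the two can be drawn; the evidence so far is only that (the limit of < 10000 nM in this assay, at which 2 of the 2 values shown sit). Compound 3, `C=CC(=O)Nc1cccc(-n2c(-c3nc(-c4cnn(C5CCN(C(=O)CO)CC5)c4)cnc3N)nc3ccccc32)c1`, is not yet measured. It differs from compound 2 by 1-((hydroxymethyl)carbonyl)piperidin-4-yl in place of methyl on an aromatic nitrogen. For the measured compounds named here, no measured step informs this change, so the expectation rests on the limit alone. The step from compound 2 to compound 3 is expected to be upward, an at least 1.5-fold higher number from compound 2 to compound 3 (0.17 log units; that floor lies within the scatter), though it may again fall within the limit. Compound 3 is estimated at 15000 nM, in the range 3000 nM to 80000 nM.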

Compound 3, solubility: < 10000 nM
Compound 3: a limit, no number (the forecaster's own chance of this, stated with the estimate: 45%); middle value at least 1.5-fold (0.17 log units) from the limit.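

No step can be read between compound 2 and compound 3 in this assay, and the two limits give no size: the limit of < 10000 nM in this assay, at which 3 of the 3 values shown sit.

The compounds shown leave open where compound 1, compound 2 and compound 3 truly lie, and whether 1-((hydroxymethyl)carbonyl)piperidin-4-yl in place of methyl on an aromatic nitrogen shifts the read-out at all.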